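A few compounds are considered here, and "the series" means these few. Any claim that something is new, unique, unknown or untested is made for them only; others in the source may bear on it.

Measured so far in a functional assay on MCF7 cells (Homo sapiens) for antiproliferative activity, read by MTT assay, with a stated time of 48 h; on this read-out lower numbers stand for stronger inhibition and higher numbers for weaker inhibition:
- Compound 1 `O=C(/C=C/c1c[nH]c2ccccc12)c1ccncc1`: 45300 nM
- Compound 2 `O=C(/C=C/c1cn(S(=O)(=O)c2ccc([N+](=O)[O-])cc2)c2ccccc12)c1ccncc1`: 14500 nM; "dose-dependent effect" (no number reported) (2 entries)
- Compound 3 `O=C(/C=C/c1cn(S(=O)(=O)c2cccc([N+](=O)[O-])c2)c2ccccc12)c1ccncc1`: 36300 nM

Compound 3, at 36300 nM, has compound 1 as its nearest neighbour on the numbers. Compound 1, at 45300 nM, lies within the usual scatter of repeated measurements of compound 3, so this pair cannot be told apart. Compound 2 shows a lower number, and its record also holds an entry without a figure: the several entries of compound 2 in this assay, 14500 nM; "dose-dependent effect" (no number reported) (2 entries).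

The next compound to be tested is compound 4 `O=C(/C=C/c1cn(S(=O)(=O)c2ccccc2[N+](=O)[O-])c2ccccc12)c1ccncc1`. It has the same atoms as compound 3, joined differently, which makes the two isomers. The change is 2-nitrophenyl in place of 3-nitrophenyl on a sulfonyl sulfur.

For the measured compounds named here, no measured pair here shows the effect of a single change, so any forecast in this assay is rough. No step beyond the scatter is expected, with compound 3 at 36300 nM as the starting point. The range stays wide on the low side, given compound 2 at 14500 nM; "dose-dependent effect" (no number reported) (2 entries). The expected change is a 1.2-fold lower number from compound 3 to compound 4 (0.08 log units; within the scatter). For compound 4 the estimated value is 30000 nM, with an expected range from 12000 nM to 70000 nM.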

Compound 4, half-maximal inhibitory concentration: 36900 nM
Estimate against measurement, compound 4: 1.2-fold (0.09 log units) below; the measured number falls inside the stated range.
By their numbers in this assay, from the lowest: compounds 3, 4 and 1 (each within the scatter of the next).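

In this assay, 2-nitrophenyl in place of 3-nitrophenyl on a sulfonyl sulfur whose other neighbour is an aromatic nitrogen gives a 1.0-fold higher number from compound 3 to compound 4 (0.01 log units; within the scatter). For the compounds shown here, this is the first pair that differs in one place only, and the step lies within the scatter, so this exchange of one group for its isomer gives no readable change and the two compounds cannot be told apart. Compound 2, a further isomer of both, has a record that holds a lower number as well as an entry without a figure: the several entries of compound 2 in this assay, 14500 nM; "dose-dependent effect" (no number reported) (2 entries)

What the nitro group itself contributes stays open, as the compounds shown give no reading in this assay for an amine or a methoxy group in its place on the phenyl ring, or for a plain phenyl. Also open, from the compounds shown here alone, is how the read-out would respond to a change elsewhere on the shared core, such as an added carboxylic acid.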